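The compounds below may be only part of what the source reports. "The series", "measured", "known", "first", "only" and "open" are said of these compounds alone.

Compound 1 `C/C=C/C(=O)N(Cc1ccc(OC)c(Br)c1)c1cc(OC)c(OC)c(OC)c1` gives 10500 nM
Compound 2 `C/C=C/C(=O)N(Cc1ccc(OC)cc1)c1cc(OC)c(OC)c(OC)c1` gives 420 nM

In a functional assay on KYSE-450 cells (Homo sapiens) for inhibition, read by MTT assay, with a stated time of 48 h (a lower number here means a stronger inhibitor, a higher number a weaker inhibitor), compound 2 (420 nM) holds the lower of the two numbers, which makes it the stronger inhibitor of the pair. Compound 3 `C/C=C/C(=O)N(Cc1ccc(OC)c(Cl)c1)c1cc(OC)c(OC)c(OC)c1` differs from it in one place: chloro in place of hydrogen on an aromatic carbon and nothing else. For the measured compounds named here, one measured step bears on this. Removing a bromo from that same carbon gave a 25-fold lower number from compound 1 to compound 2 (1.40 log units; beyond the scatter) and this large step points to a halogen there weakening inhibition. Going by the values given here, a rise in this assay is therefore expected, though no chloro compound has been measured and the evidence is a single pair. The rise is expected to be somewhat smaller than the bromo step, and the estimate is a 7.1-fold higher number from compound 2 to compound 3 (0.85 log units; beyond the scatter) as the likely change. For compound 3 the expected value is 3000 nM (estimated range 800 nM to 11000 nM).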

Compound 3, half-maximal inhibitory concentration: 10100 nM
Compound 3: middle estimate off by 3.4-fold (0.53 log units), on the low side; the range from low to high includes it.
By their numbers in this assay, from the lowest: compound 2; then compounds 3 and 1 (each within the scatter of the next).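

In this assay, chloro on this aromatic carbon, ortho to a methoxy group, gives a 24-fold higher number from compound 2 to compound 3 (1.38 log units; beyond the scatter) and so shows that the weakening seen with bromo is not unique to bromo. Exchanging one halogen for the other gives a 1.0-fold lower number from compound 1 to compound 3 (0.02 log units; within the scatter) and so leaves chloro and bromo indistinguishable at this position. The earlier reading rested on one pair; now two halogens, compared with hydrogen on the same carbon, point the same way.

On these data alone, whether fluoro, a methyl group or an amine on this carbon would also weaken inhibition remains open, so it is unclear whether the effect belongs to halogens or to any group placed here. Nothing available explains why chloro and bromo weaken inhibition at this position.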